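Swapping methyl for hydroxy on the aryl nitrogen substituent

The source may report more compounds than this note shows. Statements on the series, on what has been measured and on what is new or still open speak of the compounds shown alone.

Three compounds sharing one core have been examined so far. For compound 1 `COc1ccc(C2=Cc3ccc(F)cc3C(CC(C)=O)N2c2ccc(F)cc2)cc1` the result in an ADME assay on TZM cells (Homo sapiens) for cytotoxicity, read by CellTiter-Glo, with a stated time of 48 h (on this read-out lower numbers stand for higher toxicity in this test and higher numbers for lower toxicity in this test), is "not determined" (no result reported). Compound 2 `COc1ccc(C2=Cc3ccc(F)cc3C(CC(C)=O)N2c2ccc([N+](=O)[O-])cc2)cc1` gives 11200 nM in this assay. Compound 3 `COc1ccc(C2=Cc3ccc([N+](=O)[O-])cc3C(CC(C)=O)N2c2ccc(C)cc2)cc1` gives 10600 nM in this assay, which places it at the low end of the two reported numbers, with compound 2 so close that the distance between them lies within the usual scatter of repeated measurements, so the two cannot be told apart on toxicity.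

Compound 4 `COc1ccc(C2=Cc3ccc([N+](=O)[O-])cc3C(CC(C)=O)N2c2ccc(O)cc2)cc1` has not yet been tested. It differs from compound 3 in a single spot: hydroxy in place of methyl on an aromatic carbon. Going by the values given here, no pair of measured compounds here shows the effect of this particular exchange, so there is no prior step to lean on. The two numbers in hand sit close together despite differing in two places at once, which hints that this assay is not very sensitive to changes at the edges of this core. On that basis, the expected step from compound 3 to compound 4 is a 1.1-fold higher number from compound 3 to compound 4 (0.05 log units; within the scatter), a change not expected to go beyond the scatter in either direction. Compound 4 is therefore estimated at 12000 nM in this assay, within a range from 5000 nM to 30000 nM.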

Compound 4, half-maximal cytotoxic concentration: 23500 nM
Estimate against measurement, compound 4: 2.0-fold (0.29 log units) below, within the range that was stated.
By their numbers in this assay, from the lowest: compounds 3 and 2 (each within the scatter of the next); then compound 4.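

In this assay, this position proves able to move the read-out: hydroxy in place of methyl gives a 2.2-fold higher number from compound 3 to compound 4 (0.35 log units; beyond the scatter) and so points toward lower toxicity in this test. Going by these compounds alone, this is the first step here that can be traced to a single change, as compound 2 and compound 3 differ in two places at once; it is modest, and as one pair of compounds it sets no general rule for the shared core. Nothing in the data at hand gives a reason for this shift.

Going by these compounds, what remains open is whether hydroxy is special here or whether other replacements for methyl would shift the number in the same way, and a methoxy group, an amine or a carboxylic acid on the same aromatic carbon would speak to that. Also open, on these data alone, is whether the step would hold with fluorine in place of the nitro group on the fused part of the core that compound 3 and compound 4 both carry.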